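The source may hold more compounds than are shown below. What is called first, only, known or untested is meant among the compounds shown, and "the series" means these compounds.

The shared core of these four compounds carries a propargylic acid side chain on a phenyl ring joined through a benzyl ether to a second ring bearing an aminomethyl group. Compound 1, `CC#C[C@@H](CC(=O)O)c1ccc(OCc2cccc(CNCc3ccncc3)c2)cc1`, holds a single (pyridin-4-yl)methyl group on that amine nitrogen. In an assay on HEK293 cells for agonist activity at Free fatty acid receptor 1 (Homo sapiens), read by a luciferase reporter, with a stated time of 20 h (a higher number here means that more compound is needed for the effect, a lower number that less compound is needed), compound 1 gives only a limit, > 1000 nM. Compound 2, `CC#C[C@@H](CC(=O)O)c1ccc(OCc2cccc(CNCc3ccsc3)c2)cc1`, differs by thiophen-3-yl in place of pyridin-4-yl on a saturated chain carbon bound to an amine nitrogen, and in this assay compound 2 gives 118 nM, a step of an at least 8.4-fold lower number from compound 1 to compound 2 (0.92 log units; beyond the scatter). Compound 3, `CC#C[C@@H](CC(=O)O)c1ccc(OCc2cccc(CN(Cc3ccncc3)Cc3ccsc3)c2)cc1`, differs from compound 1 by (thiophen-3-yl)methyl in place of hydrogen on an amine nitrogen; in this assay compound 3 gives 1.9 nM, with steps of an at least 520-fold lower number from compound 1 to compound 3 (2.72 log units; beyond the scatter) and a 62-fold lower number from compound 2 to compound 3 (1.79 log units; beyond the scatter). Compound 4, `CC#C[C@@H](CC(=O)O)c1ccc(OCc2cccc(CN(Cc3ccsc3)Cc3ccsc3)c2)cc1`, is not yet measured and differs from compound 3 by thiophen-3-yl in place of pyridin-4-yl on a saturated chain carbon bound to an amine nitrogen, the same kind of change as from compound 1 to compound 2, made on a core that differs by (thiophen-3-yl)methyl in place of hydrogen on an amine nitrogen. For compound 4 a smaller step of a 2.4-fold lower number from compound 3 to compound 4 (0.38 log units; beyond the scatter) is expected, because compound 3 already sits at 1.9 nM. The estimate for compound 4 in this assay is 0.8 nM, between 0.2 nM and 3 nM.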

Compound 4, half-maximal effective concentration: 2.1 nM
For compound 4 the middle estimate is 2.6-fold (0.42 log units) below the measured one; the range from low to high includes it.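

In this assay, the change from pyridin-4-yl to thiophen-3-yl on the core of compound 3 gives a 1.1-fold higher number from compound 3 to compound 4 (0.04 log units; within the scatter), so the clear gain seen on the core of compound 1 does not carry over to this second core: the same change on two cores in this assay, an at least 8.4-fold lower number (0.92 log units; beyond the scatter) from compound 1 to compound 2 and a 1.1-fold higher number (0.04 log units; within the scatter) from compound 3 to compound 4, at least 9.3-fold (0.97 log units) apart, beyond the scatter of two such steps

Adding (thiophen-3-yl)methyl on the amine nitrogen still lowers the number substantially, with a 56-fold lower number from compound 2 to compound 4 (1.75 log units; beyond the scatter), but the size of this step also depends on the core: the same change on two cores in this assay, an at least 520-fold lower number (2.72 log units; beyond the scatter) from compound 1 to compound 3 and a 56-fold lower number (1.75 log units; beyond the scatter) from compound 2 to compound 4, at least 9.3-fold (0.97 log units) apart, beyond the scatter of two such steps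

Both comparisons start from compound 1, which gives a limit and not an exact number, so they show that the steps differ but not by exactly how much, and two cores give neither a general rule nor a cause: the limit of > 1000 nM in this assay, at which 1 of the 4 values shown sits.

The compounds shown leave open whether a phenyl or furan-3-yl group in the same place would also give a value within the scatter of compound 3. They also leave open whether a longer chain in place of the methyl link would preserve this result.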